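The source may hold more compounds than are shown below. What is called first, only, known or untested is meant among the compounds shown, and "the series" means these compounds.

Measured in an ADME assay on AGS cells (Homo sapiens) for cytotoxicity, read by neutral red uptake, with a stated time of 24 h; a higher number here means a weaker inhibitor, a lower number a stronger inhibitor:
- compound 1 `CC(C)C(=O)Oc1c(C(C)C)cc2c3c1OC(=O)[C@@]31CCCC(C)(C)[C@@H]1CC2`: 105000 nM
- compound 2 `CCC(=O)Oc1c(C(C)C)cc2c3c1OC(=O)[C@@]31CCCC(C)(C)[C@@H]1CC2`: 113000 nM

Within the data shown here, compound 2 stands level with compound 1 within the scatter, and these are the only two numbers. The next change, to compound 3 `CCCCCCCCCCCC(=O)Oc1c(C(C)C)cc2c3c1OC(=O)[C@@]31CCCC(C)(C)[C@@H]1CC2`, is nonyl in place of hydrogen on a saturated chain carbon, two bonds along the chain from a carbonyl carbon, on a saturated chain carbon, two bonds along the chain from a carbonyl carbon. Among the measured compounds shown here, the one measured step that bears on it is a 1.1-fold higher number from compound 1 to compound 2 (0.03 log units; within the scatter). That step, hydrogen in place of methyl, is a far smaller change than nonyl, so it offers only weak guidance and the range stays wide. No shift beyond the scatter is expected in this assay. The expected step is a 1.0-fold lower number from compound 2 to compound 3 (0.01 log units; within the scatter). For compound 3 the estimated value is 110000 nM, with an expected range of 45000 nM to 250000 nM.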

Compound 3, half-maximal inhibitory concentration: 413000 nM
The estimate for compound 3 lay 3.8-fold (0.57 log units) below the measured number; the measured number lies above the stated range.
By their numbers in this assay, from the lowest: compounds 1 and 2 (each within the scatter of the next); then compound 3.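

At this position in this assay, a long chain does shift the number, which the small change between compound 1 and compound 2 did not show. Nonyl in place of hydrogen gives a clear step (a 3.7-fold higher number from compound 2 to compound 3 (0.56 log units; beyond the scatter)), and undecyl in place of isopropyl on a carbonyl carbon gives a step of similar size (a 3.9-fold higher number from compound 1 to compound 3 (0.59 log units; beyond the scatter)), so compound 3 is the weakest inhibitor of the three. Nothing available explains this shift.

On these data alone, whether the number climbs steadily with chain length or jumps at some intermediate chain remains open. So does the effect of an amine or a carboxylic acid at the end of the chain.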